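This account rests on a few compounds, and the source may have more. Where it says the series, first, only, none or still open, it means among the compounds named here.

Working notes on the series. For the measured compounds named here, in a functional assay on HeLa cells (Homo sapiens) for inhibition, read by CCK-8 assay, with a stated time of 72 h, tested at 8 uM (a higher number here means more inhibition of growth at the concentration tested, a lower number less inhibition of growth), compound 1 (`Cc1ccc(SCc2ccc(C(=O)Nc3ccccc3N)cc2)cc1`) gives 79.2% and compound 2 (`Nc1ccccc1NC(=O)c1ccc(CSc2ccc(F)cc2)cc1`) gives 79.3%, so compound 2 stands level with compound 1 on the numbers so far. Compound 3 (`Cc1cc(C)cc(SCc2ccc(C(=O)Nc3ccccc3N)cc2)c1`) is still unmeasured and carries 3,5-dimethylphenyl in place of 4-fluorophenyl on a sulfur. Going by the values given here, only one measured step bears on this change, a number 0.1 percentage points higher from compound 1 to compound 2 (within the scatter), and it also alters the aromatic group on the sulfur. Among the compounds with values here, no measured compound carries the 3,5-dimethylphenyl group, so this single small step is thin support. No shift beyond the scatter is expected in this assay, in either direction, and the expected step is a number 1.3 percentage points lower from compound 2 to compound 3 (within the scatter). Compound 3 is estimated at 78%, with an expected range of 67% to 87%.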

Compound 3, percent growth inhibition at one concentration: 78.9%
The estimate for compound 3 lay 0.9 percentage points below the measured number; the measured number falls inside the stated range.
By their numbers in this assay, from the lowest: compounds 3, 1 and 2 (each within the scatter of the next).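

In this assay, 3,5-dimethylphenyl in place of 4-fluorophenyl on a sulfur gives a number 0.4 percentage points lower from compound 2 to compound 3 (within the scatter), and the same group, set against the aromatic group on the sulfur of the other measured compound, gives a number 0.3 percentage points lower from compound 1 to compound 3 (within the scatter). For the compounds shown here, the earlier pair held only 4-methylphenyl and 4-fluorophenyl at this place; compound 3 extends the set to 3,5-dimethylphenyl, with 8 heavy atoms against 7 for 4-fluorophenyl, and no step among the three compounds lies beyond the scatter. Nothing measured here explains why these aromatic groups give such closely matched numbers.

Open, on these data alone, is whether a group of another kind on the sulfur, such as an amine, a carboxylic acid or a longer chain, would give a step beyond the scatter. Also open, as far as these compounds go, is whether this tolerance would persist with an oxygen in place of the sulfur.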